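Reshaping the amide amine in a fatty acid receptor agonist

This account rests on a few compounds, and the source may have more. Where it says the series, first, only, none or still open, it means among the compounds named here.

Three compounds share a core and differ only in the amine attached to the carbonyl of a thiophene. Compound 1 `CC#CC(CC(=O)O)c1ccc(OCc2ccc(C(=O)N3CCN(c4ccccc4)CC3)s2)cc1` carries a phenyl on the ring nitrogen, and in a functional assay on HEK293 cells for agonist activity at Free fatty acid receptor 1 (Homo sapiens), read by fluorescence and calcium flux (on this read-out higher numbers stand for an effect only at larger amounts of compound and lower numbers for an effect already at smaller amounts), compound 1 gives 72 nM. Compound 3 `CC#CC(CC(=O)O)c1ccc(OCc2ccc(C(=O)N3CCN(c4cccc([N+](=O)[O-])c4)CC3)s2)cc1` carries a nitrophenyl instead, and in this assay compound 3 gives 187 nM. Compound 2 `CC#CC(CC(=O)O)c1ccc(OCc2ccc(C(=O)N3CCN(C)CC3)s2)cc1` carries only a methyl on that nitrogen, and in this assay compound 2 gives > 5000 nM, which is a limit of the assay rather than a number (the limit of > 5000 nM in this assay, at which 1 of the 3 values shown sits). Compound 2 therefore stands apart from the other two: the step of an at least 69-fold higher number from compound 1 to compound 2 (1.84 log units; beyond the scatter) and the step of an at least 26-fold lower number from compound 2 to compound 3 (1.42 log units; beyond the scatter) both separate it widely from the compounds that bear an aromatic ring on the amine.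

Compound 4 `CC#CC(CC(=O)O)c1ccc(OCc2ccc(C(=O)N3CCc4ccccc4C3)s2)cc1` is not yet measured. The change from compound 2 to compound 4 is 1,2,3,4-tetrahydroisoquinolin-2-yl in place of 4-methylpiperazin-1-yl on a carbonyl carbon. This change removes the methylated ring nitrogen and again brings an aromatic ring onto the amide amine, as in compound 1 and compound 3. Given the large steps of an at least 69-fold higher number from compound 1 to compound 2 (1.84 log units; beyond the scatter) and an at least 26-fold lower number from compound 2 to compound 3 (1.42 log units; beyond the scatter), a large step down in this assay is expected for compound 4, estimated as an at least 33-fold lower number from compound 2 to compound 4 (1.52 log units; beyond the scatter). Compound 4 is accordingly expected to give about 150 nM in this assay, between 40 nM and 700 nM.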

Compound 4, half-maximal effective concentration: 57 nM
For compound 4 the middle estimate is 2.6-fold (0.42 log units) above the measured one; the measured number falls inside the stated range.
By their numbers in this assay, from the lowest: compounds 4 and 1 (each within the scatter of the next); then compound 3. At a limit, above all of these: compound 2.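

The step of an at least 87-fold lower number from compound 2 to compound 4 (1.94 log units; beyond the scatter) shows that recovery at this position on the carbonyl carbon does not depend on a second ring nitrogen. The 1,2,3,4-tetrahydroisoquinolin-2-yl group has only one nitrogen and no hydrogen-bond acceptor, yet its six-membered aromatic ring of carbon only restores activity as the aromatic groups of compound 1 and compound 3 did. In this assay compound 4 gives 57 nM and compound 1 gives 72 nM, two values within the usual scatter of each other, so the piperazine ring of compound 1 can be exchanged for this different amine without a change that can be read. The size of the step remains a lower bound, since the value of compound 2 is a limit and not a number: the limit of > 5000 nM in this assay, at which 1 of the 4 values shown sits.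

The compounds shown do not separate the aromatic ring from the larger number of carbon atoms that comes with it, a question that a cyclohexyl on the ring nitrogen or a plain piperidine amide would address. They also leave open how a benzyl group on that nitrogen, or a hydroxyl or methoxy on the aromatic ring of the 1,2,3,4-tetrahydroisoquinolin-2-yl group, would read in this assay.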